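The compounds below may be only part of what the source reports. "The series", "measured", "known", "first", "only" and "open" are said of these compounds alone.

Three compounds built on one shared core were measured in a functional assay on MGC-803 cells (Homo sapiens) for antiproliferative activity, read by CCK-8 assay, with a stated time of 72 h, tested at 2 uM; on this read-out lower numbers stand for a weaker effect and higher numbers for a stronger effect at the one concentration tested. Compound 1 `Nc1ccccc1NC(=O)c1ccc(CSC(=S)N2CCN(c3ccccc3)CC2)cc1` gives 42.3%, the lowest of the three numbers shown. Compound 2 `Nc1ccccc1NC(=O)c1ccc(CSC(=S)N2CCc3cc(Cl)ccc32)cc1` gives 57.7%, and compound 3 `CC1CCCCN1C(=S)SCc1ccc(C(=O)Nc2ccccc2N)cc1` gives 64.4%; each of these two stands beyond the scatter above compound 1. For the measured compounds named here, the only step between measured compounds that differ in a single place is a number 6.7 percentage points higher from compound 2 to compound 3 (within the scatter), a change on the thiocarbonyl carbon that stays within the scatter.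

Compound 4 `Nc1ccccc1NC(=O)c1ccc(CSC(=S)N2CCN(Cc3ccncc3)CC2)cc1` has not yet been measured. It differs from compound 1 in one place: (pyridin-4-yl)methyl in place of phenyl on an amine nitrogen in a ring. Going by the values given here, no measured step touches this ring nitrogen, so the step from compound 2 to compound 3 bears on it only loosely, as a sign that swapping one nitrogen-bound ring group for another elsewhere on the core moved the number little. With nothing closer to go on, the expected step is a number 2.7 percentage points higher from compound 1 to compound 4 (within the scatter), that is, no step beyond the scatter. Compound 4 is therefore estimated at 45%, with a range from 30% to 62%.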

Compound 4, a percentage reported as inhibition, at one concentration (the size of the read-out at that concentration, not a potency): 18.4%
For compound 4 the middle estimate is 26.6 percentage points above the measured one, and the stated range ends above it.
By their numbers in this assay, from the lowest: compound 4; then compound 1; then compounds 2 and 3 (each within the scatter of the next).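

In this assay, the amine nitrogen in a ring turns out to be a place where the number responds: putting (pyridin-4-yl)methyl in place of phenyl gives a number 23.9 percentage points lower from compound 1 to compound 4 (beyond the scatter). The earlier compounds held no step at this nitrogen, and their only single-place step stayed within the scatter, so this is the first single change shown to move the number beyond it. The entering group differs in two ways at once, with an added carbon and a nitrogen in the aromatic ring, and nothing available explains the loss.

Benzyl on the same nitrogen would carry the added carbon without the ring nitrogen, while pyridin-4-yl would carry the ring nitrogen without the added carbon. Those two groups could show which difference goes with the lower number.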